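Replacing an anilide with an ester on a shared core

This account rests on a few compounds, and the source may have more. Where it says the series, first, only, none or still open, it means among the compounds named here.

Three measured compounds share one core and differ only in the group on the carbonyl carbon. Compound 1 `COc1ccc(-n2nc(C(=O)N3CCCCC3)cc2-c2ccc(Cl)cc2)nn1` carries piperidin-1-yl there, and in a functional assay on a cell-free system (Platelet, plasma, Homo sapiens) for inhibition, read by turbidimetry, with a stated time of 3 min (on this read-out lower numbers stand for stronger inhibition and higher numbers for weaker inhibition), compound 1 gives 41 nM. Compound 2 `COc1ccc(-n2nc(C(=O)N3CCOCC3)cc2-c2ccc(Cl)cc2)nn1` carries morpholin-4-yl and gives 83 nM. Compound 3 `COc1ccc(NC(=O)c2cc(-c3ccc(Cl)cc3)n(-c3ccc(OC)nn3)n2)cc1` carries (4-methoxyphenyl)amino and gives 400 nM, the highest of the three numbers: a 9.8-fold higher number from compound 1 to compound 3 (0.99 log units; beyond the scatter) and a 4.8-fold higher number from compound 2 to compound 3 (0.68 log units; beyond the scatter), while a 2.0-fold higher number from compound 1 to compound 2 (0.31 log units; beyond the scatter).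

Compound 4 `COc1ccc(-n2nc(C(=O)OCCC(C)C)cc2-c2ccc(Cl)cc2)nn1` has not yet been measured. Its change from compound 3 is isopentyloxy in place of (4-methoxyphenyl)amino on a carbonyl carbon. Going by the values given here, no measured step swaps an amine for an alkoxy group on that carbon, so the only guidance is indirect: both measured departures from (4-methoxyphenyl)amino gave lower numbers than compound 3, which points towards a lower number for compound 4 as well. The isopentyloxy group is, however, unlike either ring amine, so a number near that of compound 3 or above it cannot be excluded. Weighing both, compound 4 is expected to give about 250 nM, within 50 nM to 1500 nM, an expected step of a 1.6-fold lower number from compound 3 to compound 4 (0.20 log units; within the scatter).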

Compound 4, half-maximal inhibitory concentration: 1330 nM
Compound 4: middle estimate off by 5.3-fold (0.73 log units), on the low side; the measured number falls inside the stated range.
By their numbers in this assay, from the lowest: compound 1; then compound 2; then compound 3; then compound 4.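

In this assay, compound 4 gives the highest number of the set, with a 3.3-fold higher number from compound 3 to compound 4 (0.52 log units; beyond the scatter), so leaving (4-methoxyphenyl)amino does not by itself lower the number at this carbonyl carbon; the outcome depends on which group enters. The gap is larger against the two ring amines, with a 16-fold higher number from compound 2 to compound 4 (1.20 log units; beyond the scatter) and a 32-fold higher number from compound 1 to compound 4 (1.51 log units; beyond the scatter), and all three compounds joined to the carbonyl carbon through nitrogen give lower numbers than the one ester, with none among these four going against that order. Nothing measured here accounts for this rise in the number.

Isopentyloxy differs from the earlier groups both in the oxygen joined to the carbonyl carbon and in its open chain, and these compounds cannot separate those two changes; isopentylamino, which keeps the same chain on a nitrogen, would address that directly. On these data alone, it also remains open whether a shorter ester such as methoxy, or a carboxylic acid on the same carbon, would give a number closer to compound 3 or to compound 4.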